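This account rests on a few compounds, and the source may have more. Where it says the series, first, only, none or still open, it means among the compounds named here.

Compound 1, `Cc1nc2ccccc2c(=O)n1NCc1nnc(/N=C/c2ccc(N(C)C)cc2)s1`: 50%
Compound 2, `Cc1nc2ccc(Br)cc2c(=O)n1NCc1nnc(/N=C/c2ccc(N(C)C)cc2)s1`: 50%
Compound 3, `CCOC(=O)CNn1c(C)nc2ccc(Br)cc2c1=O`: 20%

In a functional assay on the whole organism (strain albino) with Rattus norvegicus as the target, in the maximal electroshock model, with a stated time of 1 h, at a dose of 30 mg/kg by the intraperitoneal route (a lower number here means less inhibition, a higher number more inhibition at the dose given (going by the name of the read-out)), compound 1 gives 50%, and compound 2 stands level with it at the digits printed, the two together being the highest of the three numbers. The step of no change at the digits printed from compound 1 to compound 2 (within the scatter), with bromo in place of hydrogen on an aromatic carbon, shows no change beyond the scatter. Going by the values given here, compound 3, a different chain on the shared core, gives 20%, a lower number that lies beyond the scatter; no single-place step connects it to compound 1.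

Compound 4, `COc1ccc(/C=N/c2nnc(CNn3c(C)nc4ccccc4c3=O)s2)cc1`, differs from compound 1 as follows: methoxy in place of dimethylamino on an aromatic carbon. Among the compounds with values here, none of the measured steps touches this position, and the only step available, from compound 1 to compound 2, is at another place and of another kind, so there is no measured guide to the size of this change. The expectation therefore rests on compound 1 alone, with 50% as the anchor. Compound 4 is estimated at 45%, in the range 25% to 65%. The step of a number 5 percentage points lower from compound 1 to compound 4 (within the scatter) is expected to stay within the scatter.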

Compound 4, a percentage reported as inhibition, in the whole organism at one dose (the size of the read-out at that dose, not a potency): 50%
Estimate against measurement, compound 4: 5 percentage points below; the range from low to high includes it.
By their numbers in this assay, from the lowest: compound 3; then compounds 1, 2 and 4 (each within the scatter of the next).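

In this assay, going by these compounds alone, methoxy in place of dimethylamino gives no change at the digits printed from compound 1 to compound 4 (within the scatter), the first measured change at this place on the six-membered aromatic ring of carbon only, para to a large group. The read-out at this dose therefore does not depend on keeping dimethylamino here: methoxy, with one heavy atom fewer and oxygen in place of nitrogen, leaves compound 4 within the scatter of compound 1. No measurement of any property of these two groups is available to account for this result.

The compounds shown leave open whether a different group at this place, such as an unsubstituted amine, a carboxylic acid or a longer alkoxy chain, would also stay within the scatter. They also leave open whether methoxy would behave the same way alongside the bromo of compound 2.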